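This account rests on a few compounds, and the source may have more. Where it says the series, first, only, none or still open, it means among the compounds named here.

Working notes on the series, values from an ADME assay on HeLa cells (Homo sapiens) for inhibition, read by MTT assay, with a stated time of 48 h; on this read-out higher numbers stand for weaker inhibition and lower numbers for stronger inhibition:
- compound 1 `CC(C)CCn1cc(/C=C/C(=O)CC(=O)C(=O)O)c2ccccc21`: > 80000 nM (a limit)
- compound 2 `O=C(/C=C/c1cn(-c2ccc(Cl)cc2)c2ccccc12)CC(=O)C(=O)O`: > 40000 nM (a limit)

Compound 2 has no number, only the limit > 40000 nM. Among the compounds with values here, the one measured step is a step that the two limits leave unreadable from compound 1 to compound 2, so it gives no size to carry forward. Compound 3 `O=C(/C=C/c1cn(Cc2ccccc2)c2ccccc12)CC(=O)C(=O)O` differs from compound 2 by benzyl in place of 4-chlorophenyl on an aromatic nitrogen. With no readable step, no change beyond the scatter is expected, and weak inhibition in this assay is expected to persist. The expected step is a step that the limit leaves unreadable from compound 2 to compound 3. Compound 3 is estimated at 60000 nM, within an expected range of 25000 nM to 120000 nM.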

Compound 3, half-maximal inhibitory concentration: > 40000 nM
Compound 3: a limit, no number (the forecaster's own chance of this, stated with the estimate: 75%); the middle value is on the limit's open side.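

Within the data shown here, compound 1, compound 2 and compound 3 all stand only as limits in this assay, and no step among them can be read. The compounds shown leave open whether isopentyl, 4-chlorophenyl and benzyl on the aromatic nitrogen differ at all in this read-out.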